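Methoxy for hydroxy on the aryl ring of compound 3

The source may report more compounds than this note shows. Statements on the series, on what has been measured and on what is new or still open speak of the compounds shown alone.

Measured compounds:
compound 1 `COc1ccc(/C=C2\CCC/C(=C\c3ccc([N+](=O)[O-])cc3)C2=O)cc1OC` gives 4300 nM
compound 2 `O=C1/C(=C/c2ccc(Cl)cc2)CCC/C1=C\c1ccc([N+](=O)[O-])cc1` gives 4100 nM
compound 3 `O=C1/C(=C/c2ccc(O)cc2)CCC/C1=C\c1ccc([N+](=O)[O-])cc1` gives 4400 nM

All three compounds share one core and were tested in a functional assay on HL-60 cells (Homo sapiens) for cytotoxicity; a lower number here means that less compound is tolerated, a higher number that more compound is tolerated. Compound 3 sits among the others: its distance to compound 1 and to compound 2 is within the scatter, so none of the three can be set apart from the rest. Going by the values given here, the only single-point step among them, a 1.1-fold higher number from compound 2 to compound 3 (0.03 log units; within the scatter), shows that exchanging chloro for hydroxy on the aromatic carbon left the number essentially unchanged.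

Compound 4 `COc1ccc(/C=C2\CCC/C(=C\c3ccc([N+](=O)[O-])cc3)C2=O)cc1` is compound 3 with methyl in place of hydrogen on an oxygen on an aromatic ring; read one bond further out, hydroxy becomes methoxy and the 4-hydroxyphenyl becomes a 4-methoxyphenyl. Compound 1 already carries a methoxy on that ring, together with a second one, and gives a number next to compound 3. The step from compound 2 to compound 3 and the closeness of compound 1 both point the same way: substituent changes on this ring have so far not moved this assay beyond the scatter.

The expectation for compound 4 is therefore a step of a 1.0-fold lower number from compound 3 to compound 4 (0.01 log units; within the scatter), that is, no change beyond the scatter. Compound 4 is estimated at 4300 nM, with a range from 2400 nM to 7800 nM.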

Compound 4, half-maximal cytotoxic concentration: > 400000 nM
Compound 4 was reported as a limit; the forecaster's own chance of this, stated with the estimate: 5%; middle value at least 93-fold (1.96 log units) away from the limit.
By their numbers in this assay, from the lowest: compounds 2, 1 and 3 (each within the scatter of the next). At a limit, above all of these: compound 4.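

In this assay compound 4 is reported only as a limit, not as a number: the limit of > 400000 nM in this assay, at which 1 of the 4 values shown sits.

Even so, methyl in place of hydrogen on the oxygen gives an at least 90-fold higher number from compound 3 to compound 4 (1.95 log units; beyond the scatter), and methoxy in place of chloro gives an at least 97-fold higher number from compound 2 to compound 4 (1.98 log units; beyond the scatter), so a place on the ring that looked silent in the exchange of chloro for hydroxy can in fact move this number by a large amount. Compound 1 shows that carrying a methoxy is not enough on its own: it has one too, yet hydrogen in place of its other methoxy gives an at least 93-fold higher number from compound 1 to compound 4 (1.96 log units; beyond the scatter), so the large step appears with the single methoxy of the 4-methoxyphenyl and not with the pair of methoxy groups.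

The compounds shown give no reason why so small a change produces a step of this size. Going by these compounds, it also stays open whether an ethoxy or an amine at the same place would behave like the methoxy of compound 4 or like the hydroxy of compound 3.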